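The compounds below may be only part of what the source reports. "The series", "measured", "known", "first", "only" and "open" are said of these compounds alone.

Measured compounds:

compound 1 `COC(=O)C[C@H](NC(=O)OC(C)(C)C)C(=O)N(Cc1ccccc1)C1(C(=O)NCc2ccccc2)CCN(Cc2ccccc2)CC1` — 19000 nM
compound 2 `CC[C@H](C)[C@H](NC(=O)OC(C)(C)C)C(=O)N(Cc1ccccc1)C1(C(=O)NCc2ccccc2)CCN(Cc2ccccc2)CC1` — 7100 nM
compound 3 `CCC(C)N(C(=O)[C@H](CC(=O)OC)NC(=O)OCc1ccccc1)C1(C(=O)NCc2ccccc2)CCN(Cc2ccccc2)CC1` — 4500 nM

In a functional assay on CCRF-CEM cells (Homo sapiens) for inhibition, with a stated time of 72 h (a lower number here means a stronger inhibitor, a higher number a weaker inhibitor), compound 1 gives 19000 nM, compound 2 gives 7100 nM and compound 3 gives 4500 nM. Compound 1 and compound 2 differ in one place, (sec-butyl in place of (methoxycarbonyl)methyl on a saturated chain carbon bound to an amide-type nitrogen and a carbonyl carbon), and this change made the step of a 2.7-fold lower number from compound 1 to compound 2 (0.43 log units; beyond the scatter). Compound 3 and compound 1 are built from the same atoms joined differently; the difference between the two cores is not broken down here. The values of compound 3 and compound 2 lie within the usual scatter of each other, so nothing can be said about their order.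

Compound 4 `CCC(C)N(C(=O)[C@@H](NC(=O)OCc1ccccc1)[C@@H](C)CC)C1(C(=O)NCc2ccccc2)CCN(Cc2ccccc2)CC1` has not yet been measured. It differs from compound 3 by sec-butyl in place of (methoxycarbonyl)methyl on a saturated chain carbon bound to an amide-type nitrogen and a carbonyl carbon, which is the same change as that from compound 1 to compound 2, at the same kind of place. If the change behaves on the core of compound 3 as it did between compound 1 and compound 2, compound 4 is expected to lie below compound 3, because compound 3 gives 4500 nM and the earlier change gave a 2.7-fold lower number from compound 1 to compound 2 (0.43 log units; beyond the scatter). The expected step is a 2.4-fold lower number from compound 3 to compound 4 (0.37 log units; beyond the scatter). Compound 4 is therefore estimated at 1900 nM in this assay, with a likely range from 800 nM to 4500 nM.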

Compound 4, half-maximal inhibitory concentration: 111000 nM
For compound 4 the middle estimate is 58-fold (1.77 log units) below the measured one; measured number outside the range, above it.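

In this assay putting sec-butyl in place of (methoxycarbonyl)methyl gives a 25-fold higher number from compound 3 to compound 4 (1.39 log units; beyond the scatter), which does not repeat what the same change did on the other core: the same change on two cores in this assay, a 2.7-fold lower number (0.43 log units; beyond the scatter) from compound 1 to compound 2 and a 25-fold higher number (1.39 log units; beyond the scatter) from compound 3 to compound 4, 66-fold (1.82 log units) apart, beyond the scatter of two such steps. Within these two pairs, neither the size nor the direction of the step carries over from the core of compound 1 to the core of compound 3, so the earlier step is no guide to this change on a different core in this series. The result does not show which difference between the two cores separates the steps, as the two cores are compared here only as wholes, and two pairs cannot establish a general rule for the series.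

The compounds shown leave open how a carboxylic acid, an amine or a longer chain would behave on a saturated chain carbon bound to an amide-type nitrogen and a carbonyl carbon on either core. They also leave open which of the two steps a third core would resemble, if either.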